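The source may report more compounds than this note shows. Statements on the series, on what has been measured and on what is new or still open speak of the compounds shown alone.

The measured compounds:

Compound 1 `COc1ccc2cc(C(C)c3nnc4n3N=C(c3ccc(C)cc3)CS4)ccc2c1`: 10200 nM
Compound 2 `Cc1ccc(C2=Nn3c(nnc3C(C)c3ccc(-c4ccccc4)c(F)c3)SC2)cc1`: 4800 nM
Compound 3 `CC(C)Cc1ccc(C(C)c2nnc3n2N=C(c2ccc(OC(F)(F)F)cc2)CS3)cc1`: 3000 nM

In a functional assay on HCT-116 cells (Homo sapiens) for inhibition, read by sulforhodamine B assay, with a stated time of 72 h (on this read-out higher numbers stand for weaker inhibition and lower numbers for stronger inhibition), compound 1 stands at the highest number of the three. Compound 2 sits at a lower number, by a margin beyond the scatter, and compound 3 sits lower still, also beyond the scatter. None of these three pairs differ in only one place, so none of them isolates a single structural change on the shared core; they show only where each compound lands.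

Compound 4 `COc1ccc2cc(C(C)c3nnc4n3N=C(c3ccc(F)cc3)CS4)ccc2c1` is the compound to be measured. It differs from compound 1 in one place: fluoro in place of methyl on an aromatic carbon, which at the level of the whole substituent reads as 4-methylphenyl going to 4-fluorophenyl. For the measured compounds named here, no measured pair carries this change, so there is nothing in the data to anchor its size or direction. The step from compound 1 is therefore expected to be small, a 1.2-fold lower number from compound 1 to compound 4 (0.08 log units; within the scatter), and may well fall within the scatter of this assay. On that basis compound 4 is estimated at 8500 nM, with a range from 3000 nM to 25000 nM.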

Compound 4, half-maximal inhibitory concentration: 13100 nM
Compound 4: middle estimate off by 1.5-fold (0.19 log units), on the low side, within the range that was stated.
By their numbers in this assay, from the lowest: compounds 3 and 2 (each within the scatter of the next); then compounds 1 and 4 (each within the scatter of the next).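

In this assay, placing fluoro instead of methyl on the aromatic carbon gives a 1.3-fold higher number from compound 1 to compound 4 (0.11 log units; within the scatter), which lies within the scatter, so 4-methylphenyl and 4-fluorophenyl cannot be told apart at this position with the rest of compound 1 held fixed. For the compounds shown here, the earlier compounds differ from one another in more than one place and could say nothing about a single group here, whereas this pair gives the first reading of one change on its own, though only for this one exchange on this one background. No supporting data are available to explain this result.

The compounds shown leave open how this position responds to a group further removed from methyl and fluoro, such as an amine, a carboxylic acid or a longer chain like n-butyl, since the only pair that speaks to it compares two single-atom substituents. They also leave open whether the exchange of methyl for fluoro would read the same with the rest of the molecule taken from compound 2, which carries the same 4-methylphenyl group.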